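The compounds below may be only part of what the source reports. "The series", "measured", "known", "first", "only" and "open" are said of these compounds alone.

Measured so far:
- compound 1 `Oc1cccc(-c2cc(-c3ccc(Cl)cc3)nc(-c3ccco3)c2)c1`: 10500 nM
- compound 2 `Oc1cccc(-c2cc(-c3ccncc3)nc(-c3ccc(Cl)cc3)c2)c1`: 3330 nM

In a functional assay on T47D cells (Homo sapiens) for cytotoxicity, read by CCK-8 assay and cell counting, with a stated time of 2 days (on this read-out lower numbers stand for stronger inhibition and higher numbers for weaker inhibition), compound 1 gives 10500 nM, the higher of the two numbers shown, and its only neighbour is compound 2 with 3330 nM. That step, a 3.2-fold lower number from compound 1 to compound 2 (0.50 log units; beyond the scatter), changes a different part of the molecule and so says little about the change in hand. Compound 3 `Oc1cccc(-c2cc(-c3ccco3)nc(-c3ccccc3Cl)c2)c1` differs from compound 1 in a single place: 2-chlorophenyl in place of 4-chlorophenyl on an aromatic carbon. Among the compounds with values here, no measured step moves the chlorine around its ring, so the expectation rests on compound 1 alone. The step of a 1.1-fold lower number from compound 1 to compound 3 (0.02 log units; within the scatter) is therefore expected to stay within the usual scatter. Compound 3 is estimated at 10000 nM, with a range from 3000 nM to 30000 nM.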

Compound 3, half-maximal inhibitory concentration: 2010 nM
Compound 3: the middle estimate sits 5.0-fold (0.70 log units) above what was measured; the whole stated range lies above it.
By their numbers in this assay, from the lowest: compounds 3 and 2 (each within the scatter of the next); then compound 1.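

In this assay, swapping 4-chlorophenyl for 2-chlorophenyl on the aromatic carbon next to the ring nitrogen gives a 5.2-fold lower number from compound 1 to compound 3 (0.72 log units; beyond the scatter), so the place of the chlorine on this ring matters even though the atoms stay the same. No supporting evidence is available to explain this shift.

From the compounds shown here alone, whether 3-chlorophenyl, or 2-methoxyphenyl with a methoxy group in the chlorine's place, would give a similar number remains open. So does whether 2-chlorophenyl would have a comparable effect with pyridin-4-yl in place of furan-2-yl.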